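Swapping one aryl substituent for another on a sigma-1 ligand

The compounds below may be only part of what the source reports. "The series", "measured", "known", "first", "only" and "open" are said of these compounds alone.

Of the compounds shown here, two have been measured in an assay on membranes from liver for displacement of a labelled ligand from Sigma non-opioid intracellular receptor 1 (Rattus norvegicus), read by scintillation counting; a higher number here means a weaker inhibitor, a lower number a stronger inhibitor. Compound 1, `COc1ccccc1CN(C)CCCCn1c(=O)oc2ccccc21`, gives 594 nM. Compound 2, `Cc1ccc(CN(C)CCCCn2c(=O)oc3ccccc32)cc1`, gives 97 nM. The two differ in one place only, and the step of a 6.1-fold lower number from compound 1 to compound 2 (0.79 log units; beyond the scatter) shows that the change of aryl group made a real difference, beyond the scatter. Among the two numbers recorded, compound 2 stands lowest, meaning it is the stronger inhibitor of the pair.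

Compound 3, `CN(CCCCn1c(=O)oc2ccccc21)Cc1cccc(Cl)c1`, is not yet measured. It keeps the whole shared core and the chain of compound 2 and changes only the aryl group: 3-chlorophenyl in place of 4-methylphenyl on a saturated chain carbon bound to an amine nitrogen. Among the measured compounds shown here, the only measured step that bears on this kind of change is a 6.1-fold lower number from compound 1 to compound 2 (0.79 log units; beyond the scatter), which involved a different pair of aryl groups. That step shows that an exchange at this position can move the number modestly, but it gives no direct reading for 3-chlorobenzyl in place of 4-methylbenzyl. For the measured compounds named here, with one earlier exchange as the sole guide, a change of no more than modest size is expected, with no clear direction, so the step of a 1.1-fold higher number from compound 2 to compound 3 (0.05 log units; within the scatter) is an estimate within or near the scatter. The number for compound 3 is estimated at 110 nM, with a likely range from 35 nM to 350 nM.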

Compound 3, inhibition constant: 302 nM
The estimate for compound 3 lay 2.7-fold (0.44 log units) below the measured number, and the stated range covers the measured number.
By their numbers in this assay, from the lowest: compound 2; then compounds 3 and 1 (each within the scatter of the next).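

In this assay, the step (a 3.1-fold higher number from compound 2 to compound 3 (0.49 log units; beyond the scatter)) shows that this position does not respond to the 4-methylphenyl group alone: an exchange that keeps a single six-membered aromatic ring of carbon only, with no hydrogen-bond donors or acceptors on either group, still moves the number beyond the scatter. The other new step (a 2.0-fold lower number from compound 1 to compound 3 (0.29 log units; within the scatter)) lies within the scatter, so the data do not separate 3-chlorophenyl from 2-methoxyphenyl on this saturated chain carbon bound to an amine nitrogen, and of the three aryl groups only 4-methylphenyl stands apart from both others. No measurement offered here accounts for the gap between these aryl groups.

Compound 2 and compound 3 differ in both the substituent and where it sits on the ring, so the effect of each cannot be told apart; 4-chlorophenyl or 3-methylphenyl would change only one of the two. Going by these compounds, how a plain phenyl group with no substituent, or a longer chain between the amine nitrogen and the shared core, would read at this receptor remains open.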